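The source may hold more compounds than are shown below. What is called first, only, known or untested is meant among the compounds shown, and "the series" means these compounds.

Compound 1 `Cc1ccc(NS(=O)(=O)c2cccc(CCCCCCNC(=O)/C=C/c3cccnc3)c2)cc1`: 1.97 nM
Compound 2 `O=C(/C=C/c1cccnc1)NCCCCCCc1cccc(S(=O)(=O)Nc2ccc(Cl)cc2)c1`: 5.94 nM

In a functional assay on MCF7 cells (Homo sapiens) for inhibition, read by CCK-8 assay, with a stated time of 72 h (a higher number here means a weaker inhibitor, a lower number a stronger inhibitor), compound 2 gives 5.94 nM, the higher of the two numbers and so the weaker inhibitor of the pair. Compound 3 `O=C(/C=C/c1cccnc1)NCCCCCCc1cccc(S(=O)(=O)Nc2ccc(C(F)(F)F)cc2)c1` has trifluoromethyl in place of chloro on an aromatic carbon, para to a large group: trifluoromethyl in place of chloro on an aromatic carbon. For the measured compounds named here, only one measured step bears on this change: a 3.0-fold higher number from compound 1 to compound 2 (0.48 log units; beyond the scatter), where chloro replaced methyl on an aromatic carbon. With this single modest step as a guide, a small further rise is expected, though it may stay within the scatter. The expected change is a 1.3-fold higher number from compound 2 to compound 3 (0.13 log units; within the scatter). The estimate for compound 3 is 8 nM, within a range from 3 nM to 22 nM.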

Compound 3, half-maximal inhibitory concentration: 67.8 nM
Estimate against measurement, compound 3: 8.5-fold (0.93 log units) below, outside the stated range (above it).
By their numbers in this assay, from the lowest: compound 1; then compound 2; then compound 3.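

In this assay this position, on an aromatic carbon para to a large group, proves far more sensitive than the first change suggested: trifluoromethyl brings an 11-fold higher number from compound 2 to compound 3 (1.06 log units; beyond the scatter) and a 34-fold higher number from compound 1 to compound 3 (1.54 log units; beyond the scatter) as well. Both steps are large, and the one from chloro to trifluoromethyl clearly exceeds the earlier one from methyl to chloro. No measurement at hand accounts for this.

The compounds shown leave open how fluoro, methoxy or an amine would read at this place. They also leave open whether the same order of methyl, chloro and trifluoromethyl would hold with a longer chain.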